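Sulfonyl aryl swap on a quinoline-free scaffold: notes

The source may hold more compounds than are shown below. What is called first, only, known or untested is meant among the compounds shown, and "the series" means these compounds.

Measured so far:
compound 1, `O=S(=O)(c1cc(Cl)cc(Cl)c1)c1cnc2cc(F)ccc2c1-c1ccccc1F`, 0.93 mL/min
compound 2, `O=S(=O)(c1cc(Cl)cc(Cl)c1)c1cnc2cc(F)ccc2c1-c1ccc(F)cc1`, 0.18 mL/min

In an ADME assay on microsomes from liver (Homo sapiens) for metabolic stability, tested at 2.5 uM (on this read-out higher numbers stand for fast clearance and lower numbers for slow clearance), compound 1 stands highest of the two numbers, and the step of a 5.2-fold lower number from compound 1 to compound 2 (0.71 log units; beyond the scatter) is the only one that has been measured; it concerns the fluorophenyl on the aromatic carbon and leaves the sulfonyl side untouched.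

Compound 3, `N#Cc1cccc(S(=O)(=O)c2cnc3cc(F)ccc3c2-c2ccccc2F)c1`, differs from compound 1 at the sulfonyl sulfur: 3-cyanophenyl in place of 3,5-dichlorophenyl on a sulfonyl sulfur. For the measured compounds named here, no measured step bears on this change; the step from compound 1 to compound 2 sits at another position, so it gives no guide to the size or direction of the sulfonyl swap. With nothing to lean on, the expectation for compound 3 is a number near that of compound 1, with a wide range either way, estimated as a 1.3-fold lower number from compound 1 to compound 3 (0.12 log units; within the scatter). Compound 3 is therefore estimated at 0.7 mL/min, between 0.2 mL/min and 2 mL/min.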

Compound 3, intrinsic clearance in a liver preparation (reported as CLH), per the amount of preparation that the assay uses: 1.39 mL/min
Compound 3: the middle estimate sits 2.0-fold (0.30 log units) below what was measured; the measured number falls inside the stated range.
By their numbers in this assay, from the lowest: compound 2; then compounds 1 and 3 (each within the scatter of the next).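

In this assay, the sulfonyl sulfur position now has a reading of its own, and this assay does not separate 3-cyanophenyl from 3,5-dichlorophenyl there (a 1.5-fold higher number from compound 1 to compound 3 (0.17 log units; within the scatter)). Chlorine atoms can thus give way to a nitrile-bearing ring on the core of compound 1 with no shift that stands clear of the usual scatter. The fluorophenyl change remains the only one of the two that is resolved (a 5.2-fold lower number from compound 1 to compound 2 (0.71 log units; beyond the scatter)), so on these compounds the read-out answers to that position and not to this sulfonyl swap. Nothing at hand explains why the two sulfonyl groups read alike.

Still open, going by these compounds, is whether 3-cyanophenyl gives the same reading when paired with the 4-fluorophenyl of compound 2. Also open, on these data alone, is whether the sulfonyl sulfur stays as undemanding with a non-aromatic group, such as a piperidine or a longer alkyl chain, in place of the aryl ring.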